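This account rests on a few compounds, and the source may have more. Where it says the series, first, only, none or still open, it means among the compounds named here.

Measured so far:
compound 1 `O=C(C1CC1)N1CCN(Cc2nc3ccccc3n2Cc2ccccc2F)CC1`, giving 40.7%
compound 2 `CC(=O)N1CCN(Cc2nc3ccccc3n2Cc2cccc(C)c2)CC1`, giving 70.3%

In an assay on isolated protein for inhibition of aldehyde dehydrogenase 1A1 (Homo sapiens), read by spectrophotometry, tested at 10 uM (on this read-out higher numbers stand for more inhibition at the one concentration tested (going by the name of the read-out) and lower numbers for less inhibition), compound 1 gives 40.7%, the lower of the two numbers; compound 2 gives 70.3%, a gap beyond the scatter. Compound 3 `O=C(C1CC1)N1CCN(Cc2nc3ccccc3n2CC2CC2)CC1` has not been measured. Compound 3 differs from compound 1 by cyclopropyl in place of 2-fluorophenyl on a saturated chain carbon bound to an aromatic nitrogen. For the measured compounds named here, no measured pair carries this change, so nothing in the numbers fixes its direction. In this assay the expected step is none beyond the scatter, with a slight lean downward, as the estimated a number 5.7 percentage points lower from compound 1 to compound 3 (within the scatter) shows. Compound 3 is expected to give 35%, in the range 10% to 60%.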

Compound 3, a percentage reported as inhibition, at one concentration (the size of the read-out at that concentration, not a potency): 21.2%
Compound 3: the middle estimate sits 13.8 percentage points above what was measured; low and high end bracket the measured number.
By their numbers in this assay, from the lowest: compound 3; then compound 1; then compound 2.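

In this assay, the group on the saturated chain carbon bound to an aromatic nitrogen clearly affects the read-out: the step is a number 19.5 percentage points lower from compound 1 to compound 3 (beyond the scatter) when cyclopropyl replaces 2-fluorophenyl. With the rest of compound 1 unchanged, this swap therefore costs inhibition beyond the scatter. No independent measurement accounts for the fall. As far as these compounds go, it remains open whether the loss tracks the aromatic ring, the fluorine or the size of the group. A plain benzyl, a 2-chlorobenzyl or a longer chain such as n-butyl at this place would help separate these.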